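Carboxyphenyl ether variants on the shared core

The source may report more compounds than this note shows. Statements on the series, on what has been measured and on what is new or still open speak of the compounds shown alone.

Compound 3 `Cc1c(OC[C@@H](C)COc2ccc(C(=O)O)cc2Cl)ccc(C(=O)CC(C)(C)C)c1O` sits second highest of the three numbers in an assay for positive allosteric modulation of metabotropic glutamate receptor 3 (Rattus norvegicus) (on this read-out higher numbers stand for an effect only at larger amounts of compound and lower numbers for an effect already at smaller amounts), where compound 3 gives 1650 nM. Compound 1 `Cc1c(OC[C@@H](C)COc2ccc(F)c(C(=O)O)c2)ccc(C(=O)CC(C)(C)C)c1O` gives 1180 nM in this assay, and compound 2 `Cc1c(OC[C@@H](C)COc2cc(C(=O)O)ccc2F)ccc(C(=O)CC(C)(C)C)c1O` gives 3950 nM. The step to compound 4 `Cc1c(OC[C@@H](C)COc2ccc(C(=O)O)c(Cl)c2)ccc(C(=O)CC(C)(C)C)c1O` is 4-carboxy-3-chlorophenyl in place of 4-carboxy-2-chlorophenyl on an oxygen on a saturated carbon. Every measured step in the series is likewise a rearrangement of carboxy and halogen on that phenyl ether: a 1.4-fold higher number from compound 1 to compound 3 (0.15 log units; within the scatter), a 3.3-fold higher number from compound 1 to compound 2 (0.52 log units; beyond the scatter) and a 2.4-fold lower number from compound 2 to compound 3 (0.38 log units; beyond the scatter). One of these three lies within the scatter and the two others are modest, so such rearrangements have so far moved this assay by at most a modest amount in either direction, and nothing in the data singles out the present change as larger. For compound 4 the step is therefore expected to be small, a 1.1-fold higher number from compound 3 to compound 4 (0.04 log units; within the scatter), with the direction uncertain. The estimate for compound 4 in this assay is 1800 nM, in a range from 700 nM to 4800 nM.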

Compound 4, half-maximal effective concentration: 860 nM
Compound 4: middle estimate off by 2.1-fold (0.32 log units), on the high side, within the range that was stated.
By their numbers in this assay, from the lowest: compounds 4, 1 and 3 (each within the scatter of the next); then compound 2.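

In this assay, moving the chlorine on the phenyl ether gives a 1.9-fold lower number from compound 3 to compound 4 (0.28 log units; within the scatter), and the change from the fluorinated isomer gives a 1.4-fold lower number from compound 1 to compound 4 (0.14 log units; within the scatter), so compounds 1, 3 and 4 cannot be told apart and 4-carboxy-3-chlorophenyl joins the arrangements that sit together on an oxygen on a saturated carbon. Among the compounds shown here, the widest step so far is a 4.6-fold lower number from compound 2 to compound 4 (0.66 log units; beyond the scatter), which leaves compound 2, with 5-carboxy-2-fluorophenyl, as the only compound whose steps to all the others lie beyond the scatter. No supporting data bear on why that arrangement stands apart.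

On these data alone, it remains open whether a tetrazole or an amide can take the place of the carboxy group. Also open, as far as these compounds go, is how bromine, methyl or trifluoromethyl would compare with the chlorine of compound 4.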